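Para-chloro on the triazole phenyl of compound 3

This account rests on a few compounds, and the source may have more. Where it says the series, first, only, none or still open, it means among the compounds named here.

Measured so far:
compound 1, `Cc1ccc(S(=O)(=O)Oc2ccc3c(c2C)[C@H](Cn2cc(-c4ccccc4)nn2)[C@@]24CC(=O)[C@@](C)(CC[C@@H]32)C4)cc1`: > 20000 nM
compound 2, `Cc1c(O)ccc2c1[C@H](Cn1cc(-c3ccc(F)cc3)nn1)[C@@]13CC(=O)[C@@](C)(CC[C@@H]21)C3`: > 20000 nM
compound 3, `C=C1C(=O)[C@]23C[C@@]1(O)CC[C@H]2c1ccc(O)c(C)c1[C@@H]3Cn1cc(-c2ccccc2)nn1`: 1320 nM

In a functional assay on SMMC-7721 cells (Homo sapiens) for cytotoxicity, read by MTT assay, with a stated time of 4 days (a higher number here means a weaker inhibitor, a lower number a stronger inhibitor), compound 1 gives only a limit, > 20000 nM. Compound 2 likewise gives only a limit, > 20000 nM. Within the data shown here, compound 3 is the one compound with a number, 1320 nM; its two companions sit at the limit of > 20000 nM in this assay, at which 2 of the 3 values shown sit, so no measured step of a single change is available.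

Compound 4, `C=C1C(=O)[C@]23C[C@@]1(O)CC[C@H]2c1ccc(O)c(C)c1[C@@H]3Cn1cc(-c2ccc(Cl)cc2)nn1`, differs from compound 3 by chloro in place of hydrogen on an aromatic carbon. Among the measured compounds shown here, with no measured step of this kind, the expected change from compound 3 to compound 4 is a 1.1-fold higher number from compound 3 to compound 4 (0.06 log units; within the scatter), a step not beyond the usual scatter. Compound 4 is therefore estimated at 1500 nM, expected between 500 nM and 5000 nM.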

Compound 4, half-maximal inhibitory concentration: 670 nM
Estimate against measurement, compound 4: 2.2-fold (0.35 log units) above; measured number inside the range.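

In this assay, among these compounds, going from phenyl to 4-chlorophenyl gives a 2.0-fold lower number from compound 3 to compound 4 (0.29 log units; within the scatter) in the first measured step at this position. The aromatic carbon thus takes a chloro in place of hydrogen with no step beyond the scatter, and compound 4 gives a number, not a limit. Compounds 1 and 2 could not show this, as neither differs from compound 3 in one place.

Going by these compounds, whether an amine or a carboxylic acid on this phenyl would move the number beyond the scatter stays open. Changes elsewhere on the core cannot be read as steps: the limit of > 20000 nM in this assay, at which 2 of the 4 values shown sit.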